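The source may hold more compounds than are shown below. What is called first, only, known or untested is meant among the compounds shown, and "the series" means these compounds.

Measured so far: compound 1 `O=C(NC(=S)Nc1cccc(-c2nc3ccccc3[nH]2)c1)c1ccccc1`, > 10000 nM; compound 2 `COc1ccc(C(=O)NC(=S)Nc2cccc(-c3nc4ccccc4[nH]3)c2)cc1OC`, 10000 nM.

In a functional assay on MDA-MB-231 cells (Homo sapiens) for inhibition, read by colorimetric assay and crystal violet staining, with a stated time of 72 h (a higher number here means a weaker inhibitor, a lower number a stronger inhibitor), compound 1 reaches only a limit of the assay, > 10000 nM. Compound 2 gives 10000 nM in this assay. Among the measured compounds shown here, the one measured step, a number no higher from compound 1 to compound 2 (the limit leaves the size open), alters the carbonyl side, and its size cannot be read because of the limit of > 10000 nM in this assay, at which 1 of the 2 values shown sits. Compound 3 `Cc1ccc(-c2nc3ccccc3[nH]2)cc1NC(=S)NC(=O)c1ccccc1` differs from compound 1 at the ring instead: methyl in place of hydrogen on an aromatic carbon. For the measured compounds named here, no measured step touches that ring, so the expected step is a step that the limit leaves unreadable from compound 1 to compound 3, nothing beyond the scatter. Compound 3 is estimated at 15000 nM in this assay, between 5000 nM and 50000 nM.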

Compound 3, half-maximal inhibitory concentration: > 10000 nM
Compound 3: a limit, no number; the forecaster's own chance of this, stated with the estimate: 70%; the middle value lies beyond the limit too.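

No step can be read from compound 1 to compound 3, because both values are only limits of the assay: the limit of > 10000 nM in this assay, at which 2 of the 3 values shown sit. The compounds shown leave open whether methyl in place of hydrogen on that aromatic carbon changes inhibition at all.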